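The source may report more compounds than this note shows. Statements on the series, on what has been measured and on what is new or still open speak of the compounds shown alone.

Among three compounds sharing one core, compound 3 `CCCCCn1c(Cc2cc(OC)c(OC)c(OC)c2)nc2c(N)nc(F)nc21` gives 286000000 nM in a functional assay on MCF7 cells (Homo sapiens) for cytotoxicity (on this read-out higher numbers stand for an effect only at larger amounts of compound and lower numbers for an effect already at smaller amounts), the highest of the three numbers. Its nearest neighbour is compound 2 `CCCCn1c(Cc2cc(OC)c(OC)c(OC)c2)nc2c(N)nc(F)nc21`, which gives 185000000 nM; the step of a 1.5-fold higher number from compound 2 to compound 3 (0.19 log units; within the scatter) lies within the scatter. Further off stands compound 1 `COc1cc(Cc2nc3c(N)ncnc3n2CCCO)cc(OC)c1OC`, which gives 92700000 nM, a gap beyond the scatter. Compound 4 `CC[C@H](C)Cn1c(Cc2cc(OC)c(OC)c(OC)c2)nc2c(N)nc(F)nc21` is not yet measured; it differs from compound 3 by sec-butyl in place of butyl on a saturated chain carbon bound to an aromatic nitrogen. Within the data shown here, only the step of a 1.5-fold higher number from compound 2 to compound 3 (0.19 log units; within the scatter) resembles this change, and it was within the scatter, so no step beyond the scatter is expected from compound 3 to compound 4 in this assay, a 1.0-fold higher number from compound 3 to compound 4 (0.02 log units; within the scatter). Compound 4 is therefore estimated at 300000000 nM, with a range from 120000000 nM to 750000000 nM.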

Compound 4, half-maximal effective concentration: 66700000 nM
For compound 4 the middle estimate is 4.5-fold (0.65 log units) above the measured one; the whole stated range lies above it.
By their numbers in this assay, from the lowest: compounds 4, 1, 2 and 3 (each within the scatter of the next, the first and the last beyond it).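

In this assay, the arrangement of the chain carbons matters at this position: with the same atoms joined differently, pentyl to 2-methylbutyl gives a 4.3-fold lower number from compound 3 to compound 4 (0.63 log units; beyond the scatter). The methyl on a saturated chain carbon bound to two saturated chain carbons gives a 2.8-fold lower number from compound 2 to compound 4 (0.44 log units; beyond the scatter), whereas the earlier methyl step from the butyl chain stayed within the scatter. Going by these compounds, whether the opposite stereocentre, a cyclohexylmethyl group or a terminal amine on the chain would give a similar number remains open. Nothing available explains this shift.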